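This account rests on a few compounds, and the source may have more. Where it says the series, first, only, none or still open, it means among the compounds named here.

Two compounds of a shared core carry different groups on the same aromatic nitrogen. Compound 1 `CC[C@H](C1CC1)n1c(=O)c(C)nc2c(-c3ccc(Cl)cc3Cl)ccnc21` bears a 1-cyclopropylpropyl group, and in a functional assay for antagonist activity at corticotropin-releasing factor receptor 1 (Rattus norvegicus) (on this read-out higher numbers stand for weaker inhibition and lower numbers for stronger inhibition), compound 1 gives 8.2 nM. Compound 2 `Cc1nc2c(-c3ccc(Cl)cc3Cl)ccnc2n(CC(C)C)c1=O` bears an isobutyl group instead, and in this assay compound 2 gives 3500 nM, the higher of the two numbers recorded, meaning weaker inhibition. Among the compounds with values here, the single step between them, a 430-fold higher number from compound 1 to compound 2 (2.63 log units; beyond the scatter), shows how much the shape of this group matters.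

Compound 3 `CC[C@@H](COC)n1c(=O)c(C)nc2c(-c3ccc(Cl)cc3Cl)ccnc21` changes the same place: 1-(methoxymethyl)propyl in place of isobutyl on an aromatic nitrogen. Like the group of compound 1, the incoming group is branched at the carbon joined to the nitrogen and carries a defined stereocentre, whereas isobutyl branches one carbon further out. Within the data shown here, the one relevant step, a 430-fold higher number from compound 1 to compound 2 (2.63 log units; beyond the scatter), was large, so a large step in the opposite direction is expected here, from compound 2 to compound 3 a fall of about a 120-fold lower number from compound 2 to compound 3 (2.07 log units; beyond the scatter). Among the measured compounds shown here, compound 3 is therefore estimated at 30 nM in this assay, with a range from 6 nM to 200 nM, the range wide since the added methoxymethyl group has no measured counterpart.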

Compound 3, half-maximal inhibitory concentration: 74 nM
Compound 3: middle estimate off by 2.5-fold (0.39 log units), on the low side; the measured number falls inside the stated range.
By their numbers in this assay, from the lowest: compound 1; then compound 3; then compound 2.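

In this assay the change from isobutyl to 1-(methoxymethyl)propyl gives a 47-fold lower number from compound 2 to compound 3 (1.67 log units; beyond the scatter), so among these three compounds both groups branched at the carbon joined to the nitrogen give far lower numbers than isobutyl, and none goes against this. The cyclopropyl ring of compound 1 is therefore not required for a low number, since an open chain holding one hydrogen-bond acceptor also reaches a much lower number than isobutyl, yet the two branched groups are not equal: a 9.0-fold higher number from compound 1 to compound 3 (0.96 log units; beyond the scatter) is a modest step, still beyond the scatter. Nothing available here explains why these groups differ.

As far as these compounds go, what the oxygen itself contributes stays open, and a 1-ethylbutyl group, with an all-carbon chain in place of the methoxymethyl arm, would be the direct comparison for compound 3. Also open, from the compounds shown here alone, are the mirror-image form of the group in compound 3 and how a longer arm, such as ethoxymethyl, would compare.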